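The source may report more compounds than this note shows. Statements on the series, on what has been measured and on what is new or still open speak of the compounds shown alone.

Measured in an assay on CHO cells for displacement of a labelled ligand from C-X-C chemokine receptor type 1 (Homo sapiens); a higher number here means a weaker inhibitor, a lower number a stronger inhibitor: compound 1 `CC[C@@H](Nc1c(Nc2cccc(C(=O)N(C)C)c2O)c(=O)c1=O)c1cc(C(C)C)co1` gives 3 nM; compound 2 `CCC(C)c1coc([C@@H](CC)Nc2c(Nc3cccc(C(=O)N(C)C)c3O)c(=O)c2=O)c1` gives 7.6 nM; compound 3 `CC[C@@H](Nc1c(Nc2cccc(C(=O)N(C)C)c2O)c(=O)c1=O)c1cc(C(C)(C)C)co1` gives 10 nM.

Compound 3 stands at the highest number of the three: the step of a 3.3-fold higher number from compound 1 to compound 3 (0.52 log units; beyond the scatter) is beyond the scatter, whereas the step of a 1.3-fold higher number from compound 2 to compound 3 (0.12 log units; within the scatter) is not. Compound 4 `CC[C@@H](Nc1c(Nc2cccc(C(=O)N(C)C)c2O)c(=O)c1=O)c1cc(C2CCCCC2)co1` differs from compound 3 by cyclohexyl in place of tert-butyl on an aromatic carbon. Within the data shown here, two measured steps bear on adding carbon at this end of the molecule, a 2.5-fold higher number from compound 1 to compound 2 (0.40 log units; beyond the scatter) and a 3.3-fold higher number from compound 1 to compound 3 (0.52 log units; beyond the scatter), both modest rises; the swap of alkyl groups on the aromatic carbon, a 1.3-fold higher number from compound 2 to compound 3 (0.12 log units; within the scatter), stayed within the scatter. A slight further rise in this assay is therefore expected for compound 4, of about a 1.5-fold higher number from compound 3 to compound 4 (0.18 log units; within the scatter), giving an estimate of 15 nM with a likely range from 6 nM to 40 nM.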

Compound 4, inhibition constant: 283 nM
Compound 4: the middle estimate sits 19-fold (1.28 log units) below what was measured; the measured number lies above the stated range.
By their numbers in this assay, from the lowest: compound 1; then compounds 2 and 3 (each within the scatter of the next); then compound 4.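

In this assay isopropyl, sec-butyl and tert-butyl on this aromatic carbon lie within modest steps of one another, but cyclohexyl gives a 28-fold higher number from compound 3 to compound 4 (1.45 log units; beyond the scatter) and a 37-fold higher number from compound 2 to compound 4 (1.57 log units; beyond the scatter) and a 94-fold higher number from compound 1 to compound 4 (1.97 log units; beyond the scatter) as well. The position therefore accepts these open-chain groups, while this six-membered carbon ring brings a far larger rise than any step among them. No measurement shown here accounts for this jump. From the compounds shown here alone, whether the rise follows from the ring itself or from its size stays open. Cyclopropyl or cyclopentyl on this carbon would help separate the two.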